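Shortening the chain of compound 1

The source may hold more compounds than are shown below. What is called first, only, known or untested is meant among the compounds shown, and "the series" means these compounds.

Compound 1 `CC/N=C(\S)NCCCCCn1nc(-c2ccccc2)ccc1=O` — 51.8 mg/kg
Compound 2 `C/N=C(/NC#N)N(C)CCCCn1nc(-c2ccccc2)ccc1=O` — a limit, > 100 mg/kg
Compound 3 `CC/N=C(/NC#N)NCCCCCn1nc(-c2ccccc2)ccc1=O` — 100 mg/kg

In a functional assay on the whole organism (stomach) with Rattus norvegicus as the target (on this read-out higher numbers stand for an effect only at larger amounts of compound and lower numbers for an effect already at smaller amounts), compound 1 gives 51.8 mg/kg, the lowest of the two numbers shown. Compound 3 gives 100 mg/kg, and the step of a 1.9-fold higher number from compound 1 to compound 3 (0.29 log units; within the scatter) lies within the scatter. Compound 2 gives only a limit of the assay, > 100 mg/kg; see (the limit of > 100 mg/kg in this assay, at which 1 of the 3 values shown sits). Compound 4 `C/N=C(\S)NCCCn1nc(-c2ccccc2)ccc1=O` differs from compound 1 by a group of 5 heavy atoms (2 carbon, 2 nitrogen, 1 sulfur; no ring) in place of a group of 8 heavy atoms (5 carbon, 2 nitrogen, 1 sulfur; no ring), on a saturated chain carbon, three bonds along the chain from an aromatic nitrogen. The measured steps of an at least 1.9-fold higher number from compound 1 to compound 2 (0.28 log units; that floor lies within the scatter) and a 1.9-fold higher number from compound 1 to compound 3 (0.29 log units; within the scatter) each exchange the terminal group on an amine nitrogen or on a saturated chain carbon four bonds along the chain from an aromatic nitrogen, and neither shortens the chain, so neither bears directly on this change. No step beyond the scatter is therefore expected. Compound 4 is expected to give about 60 mg/kg, between 25 mg/kg and 150 mg/kg. That expectation corresponds to a 1.2-fold higher number from compound 1 to compound 4 (0.06 log units; within the scatter).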

Compound 4, dose for half-maximal effect: > 100 mg/kg
Compound 4 ended at the assay's limit (the forecaster's own chance of this, stated with the estimate: 25%); at least 1.6-fold (0.22 log units) between middle value and limit.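

In this assay, among these compounds, the group of 5 heavy atoms in place of the group of 8 heavy atoms gives an at least 1.9-fold higher number from compound 1 to compound 4 (0.28 log units; that floor lies within the scatter), the first reading of a shorter chain at this position, and that floor alone does not establish a real loss. Compound 4 stands at a limit of the assay, > 100 mg/kg. Compound 4 thus adds to the values held at that limit: the limit of > 100 mg/kg in this assay, at which 2 of the 4 values shown sit.

On these data alone, how far compound 4 lies past that limit stays open. So does how a longer chain, or an amine at the chain end, would read at this position.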